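Isobutoxy in place of phenylpiperazine on the shared core

This account rests on a few compounds, and the source may have more. Where it says the series, first, only, none or still open, it means among the compounds named here.

Measured so far:
compound 1, `CC(C(=O)NCc1ccc(C(F)(F)Cl)nc1N1CCCCCC1)c1ccc(NS(C)(=O)=O)c(F)c1`: 0.5 nM
compound 2, `CC(C(=O)NCc1ccc(C(F)(F)Cl)nc1N1CCN(c2ccccc2)CC1)c1ccc(NS(C)(=O)=O)c(F)c1`: 0.8 nM
compound 3, `CC(C)COc1nc(C(F)(F)Cl)ccc1CNC(=O)C(C)c1ccc(NS(C)(=O)=O)c(F)c1`: to be measured

In an assay on CHO cells for antagonist activity at transient receptor potential cation channel subfamily V member 1 (Homo sapiens), read by FLIPR (a lower number here means a stronger inhibitor, a higher number a weaker inhibitor), compound 1 gives 0.5 nM and compound 2 gives 0.8 nM. Within the data shown here, the one measured step, a 1.6-fold higher number from compound 1 to compound 2 (0.20 log units; within the scatter), exchanged one saturated amine ring for another on the aromatic carbon next to the ring nitrogen without a change beyond the scatter. Compound 2 thus holds the higher of the two numbers, but the two values cannot be ordered.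

Compound 3 carries the change (isobutoxy in place of 4-phenylpiperazin-1-yl on an aromatic carbon). Among the measured compounds shown here, the only step that bears on it is a 1.6-fold higher number from compound 1 to compound 2 (0.20 log units; within the scatter), and it was flat; it involved two ring-bearing amine groups, whereas the incoming isobutoxy has no ring and one hydrogen-bond acceptor, so the measured step is only a partial guide. For the measured compounds named here, the series gives no example of an ether at this position.

Expectation: the step is estimated as a 2.5-fold higher number from compound 2 to compound 3 (0.40 log units; beyond the scatter), a modest rise in the number, with wide uncertainty. Compound 3 is estimated at 2 nM, within a range from 0.5 nM to 10 nM.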

Compound 3, inhibition constant: 0.6 nM
Beside the measured number, compound 3's estimate is 3.3-fold (0.52 log units) above it; low and high end bracket the measured number.
By their numbers in this assay, from the lowest: compounds 1, 3 and 2 (each within the scatter of the next).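

In this assay, among these compounds, the earlier compounds showed only two ring-bearing amine groups on this aromatic carbon next to the ring nitrogen, so they could not show whether a ring or an amine attachment was needed there. Isobutoxy has no ring and is attached through oxygen, and with 5 heavy atoms it replaces a group of 12 heavy atoms, yet the exchange for 4-phenylpiperazin-1-yl gives a 1.3-fold lower number from compound 2 to compound 3 (0.12 log units; within the scatter), and the exchange for azepan-1-yl gives a 1.2-fold higher number from compound 1 to compound 3 (0.08 log units; within the scatter). Neither a ring nor an amine attachment at this position is therefore needed to keep the number in this range, and the three groups cannot be ordered in this assay; no measurement is at hand that would explain this flatness.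

The compounds shown leave open how small the group at this position can become, which methoxy or a lone hydrogen would test, and whether a group such as a carboxylic acid or a primary amine on a chain would fit the same flat picture. Going by these compounds, all of this rests on three compounds in a single assay, with the rest of the shared core unchanged, so whether the same holds with other groups elsewhere on the core also remains open.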